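Naphthalene in place of phenyl on the oxalamide anilide

A few compounds are considered here, and "the series" means these few. Any claim that something is new, unique, unknown or untested is made for them only; others in the source may bear on it.

Compound 1 `C[C@H](NC(=O)C(=O)Nc1ccccc1)C(=O)N[C@@H](CC(=O)O)C(=O)COc1c(F)c(F)cc(F)c1F` carries a plain anilide at the outer end of its oxalamide. In a functional assay on THP-1 cells (Homo sapiens) for inhibition (on this read-out lower numbers stand for stronger inhibition and higher numbers for weaker inhibition), compound 1 gives 140 nM, the lowest of the two numbers given here. Compound 3 `C[C@H](NC(=O)C(=O)Nc1ccccc1Cc1ccccc1)C(=O)N[C@@H](CC(=O)O)C(=O)COc1c(F)c(F)cc(F)c1F` bears a benzyl group on that aromatic ring; in this assay compound 3 gives 540 nM. Compound 2 `C[C@H](NC(=O)C(=O)Nc1ccccc1-c1ccc[nH]1)C(=O)N[C@@H](CC(=O)O)C(=O)COc1c(F)c(F)cc(F)c1F` carries a 1H-pyrrol-2-yl group on the same ring, and for compound 2 this assay reports only a limit, > 32000 nM (the limit of > 32000 nM in this assay, at which 1 of the 3 values shown sits). The two measured steps from compound 1 both point the same way: a 3.9-fold higher number from compound 1 to compound 3 (0.59 log units; beyond the scatter) and an at least 220-fold higher number from compound 1 to compound 2 (2.35 log units; beyond the scatter).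

Compound 4 `C[C@H](NC(=O)C(=O)Nc1cccc2ccccc12)C(=O)N[C@@H](CC(=O)O)C(=O)COc1c(F)c(F)cc(F)c1F` changes the anilide itself: naphthalen-1-yl in place of phenyl on an amide-type nitrogen. Going by the values given here, no measured pair shows this exact exchange, but both steps that enlarge the anilide ring of compound 1 raise the number, one modestly and one by a large amount. The fused second ring of compound 4 is closer in size to the benzyl of compound 3 than to the pyrrolyl of compound 2, so a modest rise is expected, a 4.3-fold higher number from compound 1 to compound 4 (0.63 log units; beyond the scatter). Compound 4 is therefore estimated at 600 nM in this assay, with a range from 150 nM to 3000 nM.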

Compound 4, half-maximal inhibitory concentration: 60 nM
Beside the measured number, compound 4's estimate is 10-fold (1.00 log units) above it, and the stated range ends above it.
By their numbers in this assay, from the lowest: compound 4; then compound 1; then compound 3. At a limit, above all of these: compound 2.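

Enlarging the aromatic group on the amide-type nitrogen does not in itself raise the number in this assay: naphthalen-1-yl in place of phenyl gives a 2.3-fold lower number from compound 1 to compound 4 (0.37 log units; beyond the scatter), the only step shown from the plain anilide that lowers it. Among these compounds, the outcome therefore goes with the particular group added and not simply with the addition of aromatic carbon. The exchange for 2-(1H-pyrrol-2-yl)phenyl gives an at least 530-fold lower number from compound 2 to compound 4 (2.72 log units; beyond the scatter), a step whose starting point is a limit and not a number: the limit of > 32000 nM in this assay, at which 1 of the 4 values shown sits.

The compounds shown leave open whether this lower number is specific to naphthalen-1-yl, since they offer no reading for naphthalen-2-yl or for a phenyl ring carrying only a methyl or methoxy group. They also leave open how this assay would respond to a ring nitrogen in the fused system, as in a quinolinyl group placed on the same amide-type nitrogen.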